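Chloro on the Aryl Piperazine of Compound 1

The compounds below may be only part of what the source reports. "The series", "measured", "known", "first", "only" and "open" are said of these compounds alone.

Compound 1 `CC(C)C1(C(C)C)NC(=O)N(CN2CCN(c3ccccc3)CC2)C1=O` gives 300 mg/kg in a functional assay on the whole organism (strain CD1) with Mus musculus as the target, in the maximal electroshock model, with a stated time of 4 h (a higher number here means that more compound is needed for the effect, a lower number that less compound is needed), the highest of the three measured values. Compound 2 `O=C1NC(c2ccccc2)(c2ccccc2)C(=O)N1CN1CCN(c2cccc(C(F)(F)F)c2)CC1` gives 100 mg/kg, and compound 3 `O=C1NC(c2ccccc2)(c2ccccc2)C(=O)N1CN1CCN(c2ccccc2)CC1` gives 100 mg/kg; both numbers stand beyond the scatter from compound 1. For the measured compounds named here, the one step measured at a single place, no change at the digits printed from compound 2 to compound 3 (within the scatter), concerns a substituent on the same aromatic ring. Compound 4 `CC(C)C1(C(C)C)NC(=O)N(CN2CCN(c3cccc(Cl)c3)CC2)C1=O` differs from compound 1 by chloro in place of hydrogen on an aromatic carbon. Going by the values given here, because the only comparable change gave no change at the digits printed from compound 2 to compound 3 (within the scatter), no step beyond the scatter is expected in this assay . Compound 4 is therefore estimated at 300 mg/kg, with a range from 150 mg/kg to 600 mg/kg. The expected step is thus no change at the digits printed from compound 1 to compound 4 (within the scatter).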

Compound 4, minimum effective dose: 100 mg/kg
Compound 4: middle estimate off by 3.0-fold (0.48 log units), on the high side; the measured number lies below the stated range.
By their numbers in this assay, from the lowest: compounds 2, 3 and 4 (each within the scatter of the next); then compound 1.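

In this assay, the change from phenyl to 3-chlorophenyl gives a 3.0-fold lower number from compound 1 to compound 4 (0.48 log units; beyond the scatter), so a group at this place on the aromatic ring can shift the dose on the core of compound 1. The earlier step at a ring substituent, no change at the digits printed from compound 2 to compound 3 (within the scatter), showed no such shift, but it involved trifluoromethyl on a different core. Nothing shown explains the step from chloro.

As far as these compounds go, it remains open whether chloro would give a similar step on the core of compound 3. From the compounds shown here alone, whether fluoro, methoxy or an amine at the same place would match chloro also remains open.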